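The source may hold more compounds than are shown below. What is called first, only, known or untested is meant among the compounds shown, and "the series" means these compounds.

Three compounds have been measured in an assay on THP-1 cells for displacement of a labelled ligand from C-C chemokine receptor type 1 (Homo sapiens); a lower number here means a stronger inhibitor, a higher number a weaker inhibitor:
compound 1, `CC(C)CCC(=O)N[C@@H](C(=O)N1CCC(c2ccc(Cl)cc2)CC1)C(C)C`, gives 26 nM;
compound 2, `CC(C)[C@@H](NC(=O)c1ccc(F)cc1)C(=O)N1CCC(c2ccc(Cl)cc2)CC1`, gives 118 nM;
compound 3, `CC(C)[C@@H](NC(=O)C1CCCC1)C(=O)N1CCC(c2ccc(Cl)cc2)CC1`, gives 70 nM.

Compound 3 stands second highest of these three numbers. Its nearest neighbour is compound 2, with a 1.7-fold lower number from compound 2 to compound 3 (0.23 log units; within the scatter), a step within the scatter; compound 1 lies further off, with a 2.7-fold higher number from compound 1 to compound 3 (0.43 log units; beyond the scatter). The remaining step, a 4.5-fold higher number from compound 1 to compound 2 (0.66 log units; beyond the scatter), is the largest seen so far.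

Compound 4, `CC(C)[C@@H](NC(=O)c1cc2ccccc2s1)C(=O)N1CCC(c2ccc(Cl)cc2)CC1`, differs from compound 3 in one place: 1-benzothiophen-2-yl in place of cyclopentyl on a carbonyl carbon. The step from compound 2 to compound 3 bears on this change, since it also exchanges an aromatic group for cyclopentyl on that carbonyl carbon, and it stayed within the scatter. Going by the values given here, no measured compound carries a bicyclic aromatic group at that position, so the effect of the added ring is untested. Compound 4 is therefore expected to fall close to compound 2 and compound 3. The expected step is a 1.4-fold higher number from compound 3 to compound 4 (0.15 log units; within the scatter), which may not exceed the scatter. Compound 4 is estimated at 100 nM, with a range from 30 nM to 350 nM.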

Compound 4, half-maximal inhibitory concentration: 58 nM
The estimate for compound 4 lay 1.7-fold (0.24 log units) above the measured number, and the stated range covers the measured number.
By their numbers in this assay, from the lowest: compound 1; then compounds 4, 3 and 2 (each within the scatter of the next, the first and the last beyond it).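

At this carbonyl carbon, in this assay, two fused aromatic rings are accepted about as well as the single saturated ring of cyclopentyl, with a 1.2-fold lower number from compound 3 to compound 4 (0.08 log units; within the scatter) as the step between them. Set against the single aromatic ring of 4-fluorophenyl, the same group gives a 2.0-fold lower number from compound 2 to compound 4 (0.31 log units; beyond the scatter) and so separates, if only just, two compounds that compound 3 could not separate from itself: compound 4 stands beyond the scatter from compound 2, while compound 3 does not. The isopentyl chain still holds its place, since a 2.2-fold higher number from compound 1 to compound 4 (0.35 log units; beyond the scatter) shows that the added ring does not reach compound 1, and neither compound 2 nor compound 3 does so either.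

Nothing available accounts for any of these steps. The compounds shown leave open how an amine, a carboxylic acid or a chain longer than isopentyl would fare on this carbonyl carbon.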